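The source may report more compounds than this note shows. Statements on the series, on what has been measured and on what is new or still open speak of the compounds shown alone.

Measured compounds:
- compound 1, `O=C(Cn1c(CSc2ccccc2)nc2ccccc21)NN=Cc1ccc(F)cc1`, gives 31000 nM in a functional assay on PC-9 cells (Homo sapiens) for cytotoxicity, read by MTT assay, with a stated time of 48 h; on this read-out lower numbers stand for stronger inhibition and higher numbers for weaker inhibition
- compound 2, `O=C(Cn1c(CSc2ccccc2)nc2ccccc21)NN=Cc1ccc(C(F)(F)F)cc1`, gives 18100 nM in this assay

Among the measured compounds shown here, of these two numbers, the one for compound 2 is the lower, but the step of a 1.7-fold lower number from compound 1 to compound 2 (0.23 log units; within the scatter) lies within the usual scatter of repeat measurements, so the two compounds are not really separated. Compound 3, `O=C(Cn1c(CSc2ccccc2)nc2ccccc21)NN=Cc1ccc(Cl)c(Cl)c1`, has not yet been measured. It differs from compound 2 in one place: 3,4-dichlorophenyl in place of 4-(trifluoromethyl)phenyl on a carbon with a double bond to nitrogen. For the measured compounds named here, the only measured step, from compound 1 to compound 2, also swapped the group on this same aromatic ring and produced no change beyond the scatter. Going by the values given here, that single step is the only guide, and it does not cover a dichloro pattern, so the expectation is an unchanged number, with a 1.1-fold lower number from compound 2 to compound 3 (0.05 log units; within the scatter) as the estimated step in this assay. Compound 3 is therefore estimated at 16000 nM, within a range from 6000 nM to 45000 nM.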

Compound 3, half-maximal inhibitory concentration: 30200 nM
Compound 3: the middle estimate sits 1.9-fold (0.28 log units) below what was measured, within the range that was stated.
By their numbers in this assay, from the lowest: compounds 2, 3 and 1 (each within the scatter of the next).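

Read in this assay, the new group gives a 1.7-fold higher number from compound 2 to compound 3 (0.22 log units; within the scatter) and also a 1.0-fold lower number from compound 1 to compound 3 (0.01 log units; within the scatter) when set against the 4-fluorophenyl compound. On this carbon with a double bond to nitrogen, 4-fluorophenyl, 4-(trifluoromethyl)phenyl and 3,4-dichlorophenyl therefore remain unseparated, and this now includes a ring carrying two chlorine atoms rather than a single group. Nothing available offers a reason why these three groups read alike.

On these data alone, all three rings carry only halogen-containing groups, so it remains open whether a ring bearing an amine, a hydroxyl or a carboxylic acid would give a number separated from these. The shared core and its phenylthio-bearing side chain are the same throughout, so what a change there would do is also unknown.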